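Solubility notes: imide in place of pyrrolidine

The source may report more compounds than this note shows. Statements on the series, on what has been measured and on what is new or still open speak of the compounds shown alone.

Measured compounds in a physicochemical assay for solubility, read by spectrophotometry, in phosphate buffer, with a stated time of 2 h, at pH 7.4; a higher number here means a more soluble compound, a lower number a less soluble compound:
compound 1 `COc1ccc2[nH]c(C(=O)N3CC(=O)N(Cc4ccccc4)[C@@H](CN4CCCCC4)C3)cc2c1` — > 25000 nM, a limit of the assay rather than a number
compound 2 `COc1ccc2[nH]c(C(=O)N3CC(=O)N(Cc4ccccc4)[C@@H](CN4CCCC4)C3)cc2c1` — > 25000 nM, likewise a limit of the assay
compound 3 `COc1ccc2[nH]c(C(=O)N3CC(=O)N(Cc4cccc(OC(F)F)c4)[C@@H](CN4CCC(C#N)CC4)C3)cc2c1` — 27900 nM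

Compound 2 therefore stands at the upper limit of this assay; two of the three values shown sit there, as summarised by the limit of > 25000 nM in this assay, at which 2 of the 3 values shown sit, and only compound 3 carries a numeric value, itself close to that limit. For the measured compounds named here, the one step measured, a step that the two limits leave unreadable from compound 1 to compound 2, is unreadable in size because both ends are limits, so it gives no scale for how much a change on the saturated chain carbon bound to a saturated ring carbon can move solubility.

Compound 4 `COc1ccc2[nH]c(C(=O)N3CC(=O)N(Cc4ccccc4)[C@@H](CN4C(=O)c5ccccc5C4=O)C3)cc2c1` is the next compound in this series. The difference is a group of 11 heavy atoms (8 carbon, 1 nitrogen, 2 oxygen; one five-membered non-aromatic ring with 1 hetero atom, one six-membered aromatic ring of carbon only) in place of a group of 5 heavy atoms (4 carbon, 1 nitrogen; one five-membered non-aromatic ring with 1 hetero atom), on a saturated chain carbon bound to a saturated ring carbon. Going by the values given here, no measured step bears directly on this change, and compound 3 differs from compound 2 in more than one place, so only its value is of use.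

Compound 4 is expected to fall below the limit in this assay, with an expected step of an at least 2.7-fold lower number from compound 2 to compound 4 (0.44 log units; beyond the scatter). The estimate for compound 4 is 9000 nM, expected between 2000 nM and 25000 nM.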

Compound 4, solubility: > 100000 nM
Compound 4 gave a limit, no number; the forecaster's own chance of this, stated with the estimate: 30%; at least 11-fold (1.04 log units) between middle value and limit.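

In this assay compound 4 gives > 100000 nM, a limit of the assay and not a number. Compound 1 and compound 2 also stand at limits, so neither step to compound 4 can be read. From the compounds shown here alone, the size and direction of the change on replacing pyrrolidin-1-yl or piperidin-1-yl with the group in compound 4 remain open.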